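A few compounds are considered here, and "the series" means these few. Any claim that something is new, unique, unknown or untested is made for them only; others in the source may bear on it.

Compound 1 `C#CC1=CC[C@@]2(C)C(=C)CCC[C@]2(C)CC1` gives 158000 nM
Compound 2 `C=C1CCC[C@]2(C)CCC(c3cn(-c4ccc(C(C)=O)cc4)nn3)=CC[C@@]12C` gives 15100 nM

In a functional assay on HeLa cells (Homo sapiens) for cytotoxicity, read by MTT assay, with a stated time of 48 h (a lower number here means a stronger inhibitor, a higher number a weaker inhibitor), compound 2 has the lower of the two numbers, and its gap to compound 1 lies beyond the usual scatter of repeat measurements. Compound 3 `C=C1CCC[C@]2(C)CCC(c3cn(-c4ccccc4C(C)=O)nn3)=CC[C@@]12C` carries 2-acetylphenyl in place of 4-acetylphenyl on an aromatic nitrogen, so compound 2 and compound 3 have the same atoms, joined differently. For the measured compounds named here, no measured pair shows such a change, so compound 2 at 15100 nM is the only guide. The expected step (a 1.3-fold higher number from compound 2 to compound 3 (0.12 log units; within the scatter)) is small, towards a higher number, and within the scatter. Compound 3 is estimated at 20000 nM (expected range 7000 nM to 60000 nM).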

Compound 3, half-maximal inhibitory concentration: 55700 nM
Compound 3: middle estimate off by 2.8-fold (0.44 log units), on the low side, within the range that was stated.
By their numbers in this assay, from the lowest: compound 2; then compound 3; then compound 1.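

In this assay, 2-acetylphenyl in place of 4-acetylphenyl on an aromatic nitrogen gives a 3.7-fold higher number from compound 2 to compound 3 (0.57 log units; beyond the scatter) while the atoms stay the same. At this position, then, the result depends on where the acetyl group sits on the phenyl ring, and not only on which atoms are present. The data available offer no measured explanation for this step. Still open, as far as these compounds go, is how a carboxylic acid or an amine would compare with the acetyl group on the phenyl ring, and how a plain phenyl group would compare with both acetylphenyl groups.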